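A few compounds are considered here, and "the series" means these few. Any claim that something is new, unique, unknown or untested is made for them only; others in the source may bear on it.

Measured so far in an ADME assay on HepG2 cells (Homo sapiens) for cytotoxicity, read by CellTiter-Glo and resazurin assay, with a stated time of 72 h; a higher number here means that more compound is needed for the effect, a lower number that less compound is needed:

- compound 1 `CCOC(=O)CCCCCOc1cccc(CN(C(=O)c2ccc(-c3cccc(N(C)C)c3)cc2)C(C)C)c1`: in this assay compound 1 gives > 26000 nM, a limit of the assay and not a number.
- compound 2 `CCOC(=O)CCCCCOc1cccc(CN(C(=O)c2ccc(-c3cccnc3)cc2)C(C)C)c1`: in this assay compound 2 gives > 26000 nM, also a limit.
- compound 3 `CCOC(=O)CCCCCOc1cccc(CN(C(=O)c2ccc(-c3ccc4cc[nH]c4c3)cc2)C(C)C)c1`: in this assay compound 3 gives > 26000 nM, again a limit.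

Compound 3 therefore stands at the same limit as the other two; no number separates them. The steps a step that the two limits leave unreadable from compound 1 to compound 2, a step that the two limits leave unreadable from compound 1 to compound 3 and a step that the two limits leave unreadable from compound 2 to compound 3 are all unreadable, since (the limit of > 26000 nM in this assay, at which 3 of the 3 values shown sit).

The next compound is compound 4 `CCOC(=O)CCCCCOc1cccc(CN(C(=O)c2ccc(-c3cccc(S(C)(=O)=O)c3)cc2)C(C)C)c1`. It differs from compound 3 as follows: 3-(methylsulfonyl)phenyl in place of 1H-indol-6-yl on an aromatic carbon.

Going by the values given here, no measured step bears on this change in a readable way: every value so far is a limit, and none of the three aryl groups tried moved the read-out off that limit. The expectation is that compound 4 also stays at the limit, with the expected step being a number no higher from compound 3 to compound 4 (the limit leaves the size open). Compound 4 is thus estimated at 26000 nM, with the range 13000 nM to 52000 nM, most likely reported only as a limit.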

Compound 4, half-maximal effective concentration: > 26000 nM
Compound 4 gave a limit, no number (the forecaster's own chance of this, stated with the estimate: 85%); the middle value sits exactly at the limit.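

Compound 4 gives > 26000 nM, a limit and not a number. Going by these compounds alone, no step linking compound 1, compound 2, compound 3 and compound 4 can be read: the limit of > 26000 nM in this assay, at which 4 of the 4 values shown sit. The compounds shown leave open whether these aryl groups differ at all in this assay.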